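From Bromo to Phenyl in a Growth Inhibition Series

This account rests on a few compounds, and the source may have more. Where it says the series, first, only, none or still open, it means among the compounds named here.

- Compound 1 `O=C(CCCCc1cn(Cc2ccc(-c3ccccc3)cc2)nn1)NO` gives 2690 nM
- Compound 2 `O=C(CCCCc1cn(Cc2cccc(Br)c2)nn1)NO` gives 6650 nM

Among the measured compounds shown here, both values come from a functional assay on HT-1080 cells (Homo sapiens) for inhibition, read by MTT assay (a lower number here means a stronger inhibitor of growth, a higher number a weaker inhibitor of growth), and they are the only numbers at hand. Of the two, compound 2 has the higher number at 6650 nM and is the weaker inhibitor of growth, with a gap to compound 1 that lies beyond the usual scatter.

Compound 3 `O=C(CCCCc1cn(Cc2cccc(-c3ccccc3)c2)nn1)NO` has not yet been measured. It differs from compound 2 in one place, by the change phenyl in place of bromo on an aromatic carbon that puts phenyl in place of bromo on an aromatic carbon, meta to a large group. For the measured compounds named here, no measured pair shows this change directly, so the data offer no step to read across. Going by the values given here, the one guide is compound 1 at 2690 nM in this assay as it also carries a phenyl group. A modest step towards a lower number is therefore expected, possibly not beyond the scatter. The expected change is a 1.8-fold lower number from compound 2 to compound 3 (0.24 log units; within the scatter) as an estimate only. For compound 3 the estimated value is 3800 nM with an expected range from 1600 nM to 9000 nM in this estimate.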

Compound 3, concentration for 50% growth inhibition: 3140 nM
Beside the measured number, compound 3's estimate is 1.2-fold (0.08 log units) above it; the range from low to high includes it.
By their numbers in this assay, from the lowest: compounds 1 and 3 (each within the scatter of the next); then compound 2.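

In this assay, the change to phenyl in place of bromo on an aromatic carbon, meta to a large group, gives a 2.1-fold lower number from compound 2 to compound 3 (0.33 log units; beyond the scatter), a modest step, and this shows directly that this position takes a six-membered aromatic ring of carbon only in place of a single bromine atom without any loss of growth inhibition. Compound 3 at 3140 nM and compound 1 at 2690 nM lie within the scatter of each other, so moving the phenyl group from where it sits in compound 1 to this position shows no readable difference in this pair. No measurement at hand explains why phenyl gives the lower number here.

As far as these compounds go, what an amine, a carboxylic acid or a pyridine ring would do on this same aromatic carbon remains open, as does whether a smaller group such as chloro or methyl would fall nearer to bromo or to phenyl. Also open, from the compounds shown here alone, is whether a longer chain on the shared core would shift these numbers, and whether the step from bromo to phenyl would keep its size there.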